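A few compounds are considered here, and "the series" means these few. Any claim that something is new, unique, unknown or untested is made for them only; others in the source may bear on it.

Compound 1 `COc1ccc2[nH]c3c(c2c1)CCNC31CCN(Cc2ccc([N+](=O)[O-])cc2F)CC1`: 5900 nM
Compound 2 `COc1ccc2[nH]c3c(c2c1)CCNC31CCN(Cc2ccc(F)cc2F)CC1`: 2000 nM
Compound 3 `COc1ccc2[nH]c3c(c2c1)CCNC31CCN(Cc2cc(F)c(F)c(F)c2)CC1`: 2600 nM

In an assay on FRT cells for positive allosteric modulation of Cystic fibrosis transmembrane conductance regulator variant N1303K (Homo sapiens), in the presence of a further agent that is not named here (a lower number here means that less compound is needed, a higher number that more compound is needed for the effect), compound 3 gives 2600 nM, the second highest of the three numbers. It sits within the scatter of compound 2, as a 1.3-fold higher number from compound 2 to compound 3 (0.11 log units; within the scatter) shows, and apart from compound 1, as a 2.3-fold lower number from compound 1 to compound 3 (0.36 log units; beyond the scatter) shows. Compound 4 `COc1ccc2[nH]c3c(c2c1)CCNC31CCN(Cc2cc(F)c(F)cc2F)CC1` differs from compound 3 by 2,4,5-trifluorophenyl in place of 3,4,5-trifluorophenyl on a saturated chain carbon bound to an amine nitrogen in a ring. The step that bears most directly on this change is a 1.3-fold higher number from compound 2 to compound 3 (0.11 log units; within the scatter), which exchanged one fluorinated phenyl for another and stayed within the scatter; the two modest steps of a 3.0-fold lower number from compound 1 to compound 2 (0.47 log units; beyond the scatter) and a 2.3-fold lower number from compound 1 to compound 3 (0.36 log units; beyond the scatter) both removed a nitro group, which does not happen here. A step within the scatter is therefore expected, a 1.1-fold lower number from compound 3 to compound 4 (0.03 log units; within the scatter). Compound 4 is estimated at 2400 nM, with a range from 1000 nM to 5500 nM.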

Compound 4, half-maximal effective concentration: 600 nM
Estimate against measurement, compound 4: 4.0-fold (0.60 log units) above; the measured number lies below the stated range.
By their numbers in this assay, from the lowest: compound 4; then compounds 2 and 3 (each within the scatter of the next); then compound 1.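

With the same atoms joined differently, 2,4,5-trifluorophenyl in place of 3,4,5-trifluorophenyl gives a 4.3-fold lower number from compound 3 to compound 4 (0.64 log units; beyond the scatter) in this assay, so the arrangement of the fluorines at this place matters, not only their number. The added fluoro gives a 3.3-fold lower number from compound 2 to compound 4 (0.52 log units; beyond the scatter), and the whole exchange of the aromatic group gives a 9.8-fold lower number from compound 1 to compound 4 (0.99 log units; beyond the scatter), which shows that this position can move the number beyond the scatter without any nitro group being involved. Nothing available here explains why this fluorine arrangement gives the lower number. Going by these compounds, it remains open whether chloro, methoxy or trifluoromethyl in these ring positions would keep the lower number.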